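A few compounds are considered here, and "the series" means these few. Any claim that something is new, unique, unknown or untested is made for them only; others in the source may bear on it.

For the measured compounds named here, in a functional assay on HepG2 cells (Homo sapiens), read by MTT assay, with a stated time of 48 h (on this read-out higher numbers stand for weaker inhibition and lower numbers for stronger inhibition), compound 1 `CCn1c(C(=O)NCCN)ccc1C(CC)(CC)c1ccc(OCC(O)C(C)(C)C)c(C)c1` gives 176 nM and compound 2 `CCn1c(C(=O)N(CCC#N)CCC#N)ccc1C(CC)(CC)c1ccc(OCC(O)C(C)(C)C)c(C)c1` gives 42000 nM as the higher of the only two numbers available. Compound 3 `C#CC(C)OC(=O)c1ccc(C(CC)(CC)c2ccc(OCC(O)C(C)(C)C)c(C)c2)n1CC` keeps the shared core and differs from compound 2 in one place, on a carbonyl carbon whose other neighbours are: aromatic carbon. The change is a group of 5 heavy atoms (4 carbon, 1 oxygen; no ring) in place of a group of 9 heavy atoms (6 carbon, 3 nitrogen; no ring), on a carbonyl carbon and the group that enters is (1-methylprop-2-yn-1-yl)oxy.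

Going by the values given here, the one measured step that bears on this is a 240-fold higher number from compound 1 to compound 2 (2.38 log units; beyond the scatter) at the same carbonyl carbon. It is large and lies beyond the scatter, so the number in this assay clearly responds to the group at this place. Among the compounds with values here, no measured compound carries an oxygen-linked group here, so the step gives no direct guide to the entering group and the uncertainty stays wide.

A clear move to a lower number is expected, though smaller than the measured step. The estimated step is an 11-fold lower number from compound 2 to compound 3 (1.02 log units; beyond the scatter) in this direction. For compound 3 the expected value is 4000 nM within an estimated range of 400 nM to 30000 nM in this read-out.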

Compound 3, half-maximal inhibitory concentration: > 50000 nM
Compound 3 gave a limit, no number (the forecaster's own chance of this, stated with the estimate: 10%); at least 12-fold (1.09 log units) between middle value and limit.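

Compound 3 gives no number in this assay, only a limit: the limit of > 50000 nM in this assay, at which 1 of the 3 values shown sits.

The swap of the nitrile-bearing group for (1-methylprop-2-yn-1-yl)oxy on the carbonyl carbon reads as an at least 1.1-fold higher number from compound 2 to compound 3 (0.07 log units; that floor lies within the scatter) and so does not separate the two compounds, which means that the oxygen-linked group brings no measurable return towards the low number of the aminoethyl amide. The comparison with the (2-aminoethyl)amino group reads as an at least 280-fold higher number from compound 1 to compound 3 (2.45 log units; beyond the scatter) and is large, so a second, quite different group now stands far from that group on the same carbonyl carbon. Among the three compounds shown, only compound 1 gives a low number in this assay, and neither of the other two goes against this.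

From the compounds shown here alone, what the low number of compound 1 depends on stays open, whether the terminal amine, the amide hydrogen or the length of the chain. A dimethylamine at the chain end, a longer aminopropyl chain or a carboxylic acid at this carbonyl carbon would each bear on that question, and the three compounds shown give no guide to any of them.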